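Dissociation notes: terminal aryl exchange on the shared core

This account rests on a few compounds, and the source may have more. Where it says the series, first, only, none or still open, it means among the compounds named here.

compound 1 `COc1ccc(Oc2ccc3c(NCCCNCc4cc(F)ccc4OC)ccnc3c2)cc1` in a physicochemical assay for acid dissociation, gives 9.28
compound 2 `COc1ccc(F)cc1CNCCCNc1ccnc2cc(Cc3ccc(F)cc3Cl)ccc12` in this assay gives 9.47
compound 3 `COc1ccc(F)cc1CNCCCNc1ccnc2cc(Cc3ccccc3)ccc12` in this assay gives 9.47

Compound 3 stands level with compound 2 at the digits printed, the two together the highest of the three numbers; the gap between them is no change at the digits printed from compound 2 to compound 3 (within the scatter). Against compound 1 the gap is a number 0.19 log units higher from compound 1 to compound 3 (within the scatter).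

Compound 4 `COc1ccc(-c2ccc3c(NCCCNCc4cc(F)ccc4OC)ccnc3c2)cc1` differs from compound 3 by 4-methoxyphenyl in place of benzyl on an aromatic carbon. Among the measured compounds shown here, the steps that bear on this change are the two earlier exchanges at the same aromatic carbon of the core, a number 0.19 log units higher from compound 1 to compound 2 (within the scatter) and a number 0.19 log units higher from compound 1 to compound 3 (within the scatter), together with the exchange on the saturated chain carbon, no change at the digits printed from compound 2 to compound 3 (within the scatter). Every one of these sits within the scatter, so no step beyond the scatter is expected in this assay for this further exchange either. Compound 4 is accordingly estimated at 9.45, with a range from 9.15 to 9.75. The step this estimate implies, a number 0.02 log units lower from compound 3 to compound 4 (within the scatter), is expected to stay within the scatter.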

Compound 4, acid dissociation constant: 9.47
Beside the measured number, compound 4's estimate is 0.02 log units below it, within the range that was stated.
By their numbers in this assay, from the lowest: compounds 1, 2, 3 and 4 (each within the scatter of the next).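

In this assay, 4-methoxyphenyl at this aromatic carbon of the shared core gives no change at the digits printed from compound 3 to compound 4 (within the scatter), no change at the digits printed from compound 2 to compound 4 (within the scatter) and a number 0.19 log units higher from compound 1 to compound 4 (within the scatter). The earlier compounds shown here held only groups with a linking atom to the ring, and this exchange adds a group without one, carrying one hydrogen-bond acceptor where benzyl carries none, yet all four compounds remain within the scatter of each other. No supporting data accompany these numbers to explain the result.

The compounds shown leave open whether a carboxylic acid or an aminomethyl group at this aromatic carbon would also stay within the scatter. They also leave open whether a longer chain in the shared core would give a step beyond it.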